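The source may report more compounds than this note shows. Statements on the series, on what has been measured and on what is new or still open speak of the compounds shown alone.

The measured compounds:
compound 1, `O=C1O/C(=C\Cn2cc(-c3cc(F)cc(F)c3)nn2)C(OCc2ccccc2)=C1OCc1ccccc1`, in a functional assay on SW-620 cells (Homo sapiens) for antiproliferative activity, read by MTT assay, with a stated time of 72 h; on this read-out lower numbers stand for stronger inhibition and higher numbers for weaker inhibition: > 100000 nM, which is a limit of the assay
compound 2, `CCCCc1cn(C[C@H](O)[C@H]2OC(=O)C(OCc3ccccc3)=C2OCc2ccccc2)nn1`, in this assay: 47500 nM
compound 3, `CC(C)(C)OC(=O)N1CCN(C(=S)SCc2cn(C[C@H](O)[C@H]3OC(=O)C(OCc4ccccc4)=C3OCc3ccccc3)nn2)CC1`, in this assay: > 100000 nM, which is a limit of the assay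

Compound 2 is the only one of the three for which this assay returns a number rather than a limit. Compound 1 and compound 3 both sit at the limit of > 100000 nM in this assay, at which 2 of the 3 values shown sit, a limit and not a measured number, so their values show only that they fall beyond the range reported by this assay.

Compound 4, `CCCCCCCCCCc1cn(C[C@H](O)[C@H]2OC(=O)C(OCc3ccccc3)=C2OCc2ccccc2)nn1`, has not yet been measured in this assay. It differs from compound 2 by hexyl in place of hydrogen on a saturated chain carbon, four bonds along the chain from an aromatic carbon. No step between two measured compounds is shown here, so there is no measured change of the same kind from which the size of the step could be read. For compound 4 the step from compound 2 is expected to be a 2.4-fold lower number from compound 2 to compound 4 (0.38 log units; beyond the scatter), a modest gain that goes somewhat beyond the usual scatter but remains uncertain in size. For compound 4 the estimated value in this assay is 20000 nM, with a range from 5000 nM to 80000 nM.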

Compound 4, half-maximal inhibitory concentration: 45200 nM
Compound 4: middle estimate off by 2.3-fold (0.35 log units), on the low side, within the range that was stated.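

In this assay, for the compounds shown here, this is the first step that can be read at this position: hexyl in place of hydrogen on a saturated chain carbon, four bonds along the chain from an aromatic carbon, gives a 1.1-fold lower number from compound 2 to compound 4 (0.02 log units; within the scatter). The chain at this place therefore carries the added hexyl with the read-out staying within the scatter, so in this one pair the added length brings no measurable change in antiproliferative activity, and compound 4, like compound 2, returns a number and not a limit. Compound 1 and compound 3 still give only a limit of the assay, not a number: the limit of > 100000 nM in this assay, at which 2 of the 4 values shown sit.

Going by these compounds, a single pair says nothing about the lengths in between, so it remains open whether a methyl or propyl addition at the same place, or a chain ending in an amine or a carboxylic acid, would also leave the read-out unchanged. On these data alone, it also remains open whether the same hexyl change would behave alike on the core of compound 1, which carries a difluorophenyl group on the aromatic ring in place of a saturated chain.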